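A few compounds are considered here, and "the series" means these few. Any claim that something is new, unique, unknown or untested is made for them only; others in the source may bear on it.

In a functional assay on PC-3 cells (Homo sapiens) for cytotoxicity, read by MTT assay, with a stated time of 72 h (a higher number here means a weaker inhibitor, a lower number a stronger inhibitor), compound 1 `Cc1ccc(S(=O)(=O)n2cc(COC3=C/C(=N\c4ccccc4)c4ccccc4C3=O)nn2)cc1` gives > 20000 nM, which is a limit of the assay and not a number. Compound 4 `Cc1ccc(S(=O)(=O)n2cc(COC3=C/C(=N\c4ccc(F)cc4)c4ccccc4C3=O)nn2)cc1` differs from it by a single change, fluoro in place of hydrogen on an aromatic carbon, para to a large group. Two measured compounds carry a comparable replacement of hydrogen. Compound 2 `CC(=O)c1ccc(/N=C2\C=C(OCc3cn(S(=O)(=O)c4ccc(C)cc4)nn3)C(=O)c3ccccc32)cc1`, with acetyl, gives 3910 nM, and compound 3 `Cc1ccc(S(=O)(=O)n2cc(COC3=C/C(=N\c4ccc(Br)cc4)c4ccccc4C3=O)nn2)cc1`, with bromo, gives 3410 nM. These two values agree within the scatter, as a 1.1-fold lower number from compound 2 to compound 3 (0.06 log units; within the scatter) shows. With an at least 5.1-fold lower number from compound 1 to compound 2 (0.70 log units; beyond the scatter) and an at least 5.8-fold lower number from compound 1 to compound 3 (0.76 log units; beyond the scatter), both beyond the scatter, a lower number is also expected for fluoro, though perhaps by less. The estimated change is an at least 2.8-fold lower number from compound 1 to compound 4 (0.45 log units; beyond the scatter). For compound 4 the expected value is 7000 nM, with an estimated range of 3000 nM to 20000 nM.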

Compound 4, half-maximal inhibitory concentration: 2030 nM
Compound 4: middle estimate off by 3.4-fold (0.54 log units), on the high side; the whole stated range lies above it.
By their numbers in this assay, from the lowest: compounds 4, 3 and 2 (each within the scatter of the next). At a limit, above all of these: compound 1.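

A single fluoro on this carbon, para to a large group, is enough for an at least 9.8-fold lower number from compound 1 to compound 4 (0.99 log units; beyond the scatter). Fluoro, bromo and acetyl cannot be told apart here, with a 1.7-fold lower number from compound 3 to compound 4 (0.23 log units; within the scatter) and a 1.9-fold lower number from compound 2 to compound 4 (0.28 log units; within the scatter), so three quite different groups at this position now give values within the scatter of one another. Compound 1 stands at a limit and not at a number: the limit of > 20000 nM in this assay, at which 1 of the 4 values shown sits.

Going by these compounds, whether an amine or a carboxylic acid at this position would give a value in the same range remains open. So does whether fluoro on another carbon of this ring would do the same.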